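Two Weak Ureas on a Shared Core, a Butoxy Analogue

The source may hold more compounds than are shown below. What is called first, only, known or untested is meant among the compounds shown, and "the series" means these compounds.

Measured so far in a functional assay on OVCAR-5 cells (Homo sapiens) for inhibition, read by sulforhodamine B assay, with a stated time of 48 h; a lower number here means a stronger inhibitor of growth, a higher number a weaker inhibitor of growth:
compound 1 `O=C(Nc1ccccc1OC(F)(F)F)Nc1n[nH]c2ccccc12`: 34300 nM
compound 2 `Nc1nn(C(=O)Nc2ccc(Cc3ccccc3)cc2)c2ccccc12`: 31300 nM
compound 3 `COc1ccccc1NC(=O)n1nc(N)c2ccccc21`: > 100000 nM

Compound 2 holds the lowest of the two plain numbers in this assay. Its nearest neighbour is compound 1, which gives 34300 nM in this assay, a gap that falls within the scatter, so the two cannot be told apart. Compound 3 is a separate case: in this assay compound 3 gives > 100000 nM, which is a limit of the assay and not a number (the limit of > 100000 nM in this assay, at which 1 of the 3 values shown sits).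

The compound yet to be measured is compound 4 `CCCCOc1ccc(NC(=O)n2nc(N)c3ccccc32)cc1`. It differs from compound 2 in one place: butoxy in place of benzyl on an aromatic carbon. Going by the values given here, no single-change step between measured compounds is available to set a size for this exchange. Compound 3, which carries a methoxy on its aromatic ring, sits at the limit. Compound 2 with its benzyl gives 31300 nM; an alkoxy group thus goes with the weaker end of what has been seen here. Compound 4 is therefore expected to land somewhat weaker than compound 2, a step of a 1.8-fold higher number from compound 2 to compound 4 (0.24 log units; within the scatter), with a real chance that only a limit is reported. The estimate for compound 4 in this assay is 55000 nM, within a range from 20000 nM to 150000 nM.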

Compound 4, concentration for 50% growth inhibition: 20000 nM
Beside the measured number, compound 4's estimate is 2.8-fold (0.44 log units) above it; measured number inside the range.
By their numbers in this assay, from the lowest: compounds 4, 2 and 1 (each within the scatter of the next). At a limit, above all of these: compound 3.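

In this assay, butoxy in place of benzyl on an aromatic carbon, para to a large group, gives a 1.6-fold lower number from compound 2 to compound 4 (0.19 log units; within the scatter), so this single change leaves no readable difference in growth inhibition. The step also shows that the aromatic ring of the benzyl group can go, and a chain with no ring and one hydrogen-bond acceptor can enter, without the number moving beyond the scatter; compound 4, with 20000 nM, therefore cannot be told apart from compound 2. Compound 3 remains a limit of the assay and not a number, so it sets no size for any change: the limit of > 100000 nM in this assay, at which 1 of the 4 values shown sits.

The compounds shown leave open whether any group at this position can move the number beyond the scatter, as one exchange gives only one step there. A shorter propoxy chain, a longer hexyloxy chain, a terminal amine or a carboxylic acid at the same place would show whether the position responds at all or stays as flat as this single pair suggests.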